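The source may hold more compounds than are shown below. What is called first, only, known or untested is meant among the compounds shown, and "the series" means these compounds.

Series notes. Compound 1 `C#Cc1cn([C@@H]2O[C@H](CO)[C@@H](O)[C@H]2O)c2ncnc(C)c12` carries methyl on the core; in an ADME assay on MRC5 cells (Homo sapiens), read by MTT assay, with a stated time of 72 h (on this read-out lower numbers stand for stronger inhibition and higher numbers for weaker inhibition), compound 1 gives 1440 nM. Compound 2 `C#Cc1cn([C@@H]2O[C@H](CO)[C@@H](O)[C@H]2O)c2ncnc(NC)c12` has methylamino in its place. In this assay compound 2 reaches only the limit > 100000 nM. Compound 3 `C#Cc1cn([C@@H]2O[C@H](CO)[C@@H](O)[C@H]2O)c2ncnc(SC)c12` likewise stops at the limit > 100000 nM in this assay. The measured steps are an at least 69-fold higher number from compound 1 to compound 2 (1.84 log units; beyond the scatter) and an at least 69-fold higher number from compound 1 to compound 3 (1.84 log units; beyond the scatter), while a step that the two limits leave unreadable from compound 2 to compound 3. Compound 2 thus sits at the limit of > 100000 nM in this assay, at which 2 of the 3 values shown sit, the weak end of the shown numbers. Compound 4 `CNc1ncnc2c1c(-c1cc3ccccc3o1)cn2[C@@H]1O[C@H](CO)[C@@H](O)[C@H]1O` differs from compound 2 by 1-benzofuran-2-yl in place of ethynyl on an aromatic carbon. Going by the values given here, no measured step touches this position; the steps on hand alter a different group of the core, so no direction can be read for this change. Compound 4 is therefore expected to stay near the limit, estimated at 80000 nM with a range of 10000 nM to 100000 nM, the expected step being an at least 1.2-fold lower number from compound 2 to compound 4 (0.09 log units; that floor lies within the scatter).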

Compound 4, half-maximal inhibitory concentration: 75300 nM
Compound 4: the middle estimate sits 1.1-fold (0.03 log units) above what was measured; the measured number falls inside the stated range.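

Going by these compounds alone, the step of an at least 1.3-fold lower number from compound 2 to compound 4 (0.12 log units; that floor lies within the scatter) is the first reading at this position, with 1-benzofuran-2-yl in place of ethynyl on the shared core. Compound 2 stands at a limit, so only a floor for this step can be read, and that floor does not go beyond the scatter. With methylamino kept, compound 4 gives a readable number in this assay rather than a limit.

Open, from the compounds shown here alone, is how 1-benzofuran-2-yl would read with methyl on the core in place of methylamino. Also open, going by these compounds, is how a nitrile, a phenyl or a longer alkyne chain would read on this aromatic carbon.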